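Phenyl for Butyl on the Sulfonyl Sulfur

The source may report more compounds than this note shows. Statements on the series, on what has been measured and on what is new or still open speak of the compounds shown alone.

Four compounds share one core, an acylated amino acid derivative bearing an imidazolylmethyl-substituted benzamide. Compound 1 `CC[C@H](C)[C@H](NC(=O)c1cccc(Cn2ccnc2)c1)c1nn[nH]n1` carries a tetrazole at the end of the chain; in an assay on HEK293 cells for displacement of a labelled ligand from Type-2 angiotensin II receptor (Homo sapiens), tested at 1 uM (a lower number here means a weaker effect, a higher number a stronger effect of the compound at the concentration tested), compound 1 is reported as "not active" (no number reported). Compound 3 `CC[C@H](C)[C@H](NC(=O)c1cccc(Cn2ccnc2)c1)C(=O)NNS(=O)(=O)c1ccc(C)cc1` extends the chain through a sulfonyl hydrazide, and in this assay compound 3 gives 4%, a read-out that sits at the low end of the scale. Compound 2 `CCCCS(=O)(=O)NC(=O)[C@@H](NC(=O)c1cccc(Cn2ccnc2)c1)[C@@H](C)CC` is the butylsulfonyl acyl sulfonamide, and in this assay compound 2 is "not determined" (no result reported), so no number places it among the others; where it stands is known only from its structure.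

Compound 4 `CC[C@H](C)[C@H](NC(=O)c1cccc(Cn2ccnc2)c1)C(=O)NS(=O)(=O)c1ccccc1` is reached from compound 2 by a single exchange (phenyl in place of butyl on a sulfonyl sulfur), giving a phenylsulfonyl amide in place of the butylsulfonyl one. Among the measured compounds shown here, no measured pair shows what such a move does in this assay, and compound 2 itself has no number, so the step has no measured anchor. Given that compound 1 and compound 3 give only weak read-outs, a small number is expected for compound 4 as well: the estimate for compound 4 in this assay is 6%, within a range from 0% to 22%.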

Compound 4, a percentage reported as inhibition, at one concentration (the size of the read-out at that concentration, not a potency): 5%
Beside the measured number, compound 4's estimate is 1 percentage points above it, within the range that was stated.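

In this assay, among the compounds shown here, the one readable step at this end of the chain is the exchange of ((4-methylphenyl)sulfonyl)amino for phenylsulfonyl on an amide-type nitrogen, which gives a number 1 percentage points higher from compound 3 to compound 4 (within the scatter), so the sulfonyl hydrazide of the earlier series and the phenylsulfonyl amide cannot be told apart at the concentration tested. For the compounds shown here, compound 2 has no reported result, so the step from butylsulfonyl to phenylsulfonyl on the sulfonyl sulfur cannot be read, and compound 4 supplies the first number for an acyl sulfonamide in this set, not a measure of what that exchange does. No measurement at hand bears on why the read-outs of compound 3 and compound 4 sit where they do.

Going by these compounds, it remains open whether a different group on the sulfonyl sulfur, such as a 4-methoxyphenyl ring, a benzyl group or a longer chain such as octyl, would give a read-out clearly apart from that of compound 4. Also open, on these data alone, is whether a carboxylic acid or a primary amide at the end of the chain, in place of the sulfonyl amide, would do so.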